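An isopropylphenyl group in place of cyanophenyl

The source may hold more compounds than are shown below. What is called first, only, known or untested is meant among the compounds shown, and "the series" means these compounds.

Of the compounds shown here, two sharing one core have been measured. Compound 1 `COc1ccc(-n2cc(COc3cccc(NC(=O)Nc4ccc(Cl)c(C(F)(F)F)c4)c3)nn2)cc1` carries a 4-methoxyphenyl group on an aromatic nitrogen, and in a functional assay on HepG2 cells (Homo sapiens) for inhibition, read by MTT assay, with a stated time of 72 h (on this read-out lower numbers stand for stronger inhibition and higher numbers for weaker inhibition), compound 1 gives 4680 nM. Compound 2 `N#Cc1cccc(-n2cc(COc3cccc(NC(=O)Nc4ccc(Cl)c(C(F)(F)F)c4)c3)nn2)c1` carries a 3-cyanophenyl group at that nitrogen, and in this assay compound 2 gives 2760 nM. For the measured compounds named here, compound 2 thus stands at the lowest of the two numbers, yet the only step, a 1.7-fold lower number from compound 1 to compound 2 (0.23 log units; within the scatter), leaves the two compounds unseparated. Compound 3 `CC(C)c1ccccc1-n1cc(COc2cccc(NC(=O)Nc3ccc(Cl)c(C(F)(F)F)c3)c2)nn1` differs from compound 2 in one place: 2-isopropylphenyl in place of 3-cyanophenyl on an aromatic nitrogen. Going by the values given here, the single step that bears on this position is the exchange of aryl groups from compound 1 to compound 2, which stayed within the scatter, so no step beyond the scatter is expected here either, as a 1.3-fold higher number from compound 2 to compound 3 (0.10 log units; within the scatter). Compound 3 is therefore expected to give about 3500 nM in this assay, with a range from 1200 nM to 10000 nM.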

Compound 3, half-maximal inhibitory concentration: 1900 nM
Compound 3: the middle estimate sits 1.8-fold (0.27 log units) above what was measured; measured number inside the range.
By their numbers in this assay, from the lowest: compounds 3, 2 and 1 (each within the scatter of the next, the first and the last beyond it).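

In this assay, the exchange of 3-cyanophenyl for 2-isopropylphenyl gives a 1.5-fold lower number from compound 2 to compound 3 (0.16 log units; within the scatter), so these two groups are not separated at this aromatic nitrogen, even though one carries a nitrile and the other only carbon. The position does now show its first step beyond the scatter, a modest one (a 2.5-fold lower number from compound 1 to compound 3 (0.39 log units; beyond the scatter)), while compound 2 stays within the scatter of both neighbours. Nothing available accounts for this gap.

The three aryl groups differ both in their substituent and in where it sits on the ring, so the two influences cannot be told apart. As far as these compounds go, whether the step would hold or grow with a group other than a substituted phenyl, such as a cyclohexyl group or a pyridine ring, remains open.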